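Sulfonamide for phenylpropylamine on an otherwise inert series

A few compounds are considered here, and "the series" means these few. Any claim that something is new, unique, unknown or untested is made for them only; others in the source may bear on it.

Three compounds built on a shared core have been examined in a functional assay on HEK293 cells (Homo sapiens) for cytotoxicity; on this read-out lower numbers stand for higher toxicity in this test and higher numbers for lower toxicity in this test. Compound 1 `COc1ccc([C@H]2CC(=O)N(c3ccc(C#N)cc3)C2)cc1OC1CCCC1` gives > 10000 nM, which is a limit of the assay rather than a number. Compound 2 `COc1ccc([C@H]2CC(=O)N(c3ccncc3)C2)cc1OC1CCCC1` likewise gives only a limit, > 10000 nM. The step that the two limits leave unreadable from compound 1 to compound 2 therefore cannot be read. Compound 3 `COc1ccc([C@H]2CC(=O)N(c3cccc(NCCCc4ccccc4)c3)C2)cc1OC1CCCC1` also stands at a limit, giving > 10000 nM in this assay. All values shown sit at the same bound (the limit of > 10000 nM in this assay, at which 3 of the 3 values shown sit). Compound 4 `COc1ccc([C@H]2CC(=O)N(c3cccc(NS(=O)(=O)c4cccc(Cl)c4)c3)C2)cc1OC1CCCC1` differs from compound 3 by (3-chlorophenyl)sulfonyl in place of 3-phenylpropyl on a nitrogen on an aromatic ring. No readable measured step bears on this change, and no movement beyond the scatter is expected; the step that the limit leaves unreadable from compound 3 to compound 4 is estimated to stay near the limit. Compound 4 is thus expected to give about 15000 nM, within 4000 nM to 60000 nM.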

Compound 4, half-maximal cytotoxic concentration: > 10000 nM
Compound 4: a limit, no number; the forecaster's own chance of this, stated with the estimate: 80%; the middle value is on the limit's open side.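

Within the data shown here, compound 4, like compound 3, gives only a limit and not a number, so no step between the two can be read. Whether any change on the shared core gives a readable value stays open, since every compound shown sits at one bound: the limit of > 10000 nM in this assay, at which 4 of the 4 values shown sit.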